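This account rests on a few compounds, and the source may have more. Where it says the series, first, only, none or still open, it means among the compounds named here.

Compound 1 `O=C(CCCCCCCCC(=O)c1ccccc1)NO`: 135 nM in an assay on isolated protein for inhibition of histone deacetylase 8 (Homo sapiens); a higher number here means a weaker inhibitor, a lower number a stronger inhibitor
Compound 2 `COc1ccc(C(=O)CCCCCCC(=O)NO)cc1`: 450 nM
Compound 3 `COc1ccc(C(=O)CCCCCCCC(=O)NO)cc1`: 15 nM

Compound 3 gives the lowest number of the three in this assay; compound 1 stands nearest to it and compound 2 furthest. Compound 4 `O=C(CCCCCCCC(=O)c1ccc(-c2ccccc2)cc1)NO` carries phenyl in place of methoxy on an aromatic carbon. Within the data shown here, the only step measured so far, a 30-fold lower number from compound 2 to compound 3 (1.48 log units; beyond the scatter), concerns the length of the chain between the two carbonyls, not the group on the ring, so nothing measured bears directly on the change from compound 3 to compound 4. Compound 1 and compound 3 differ in two places at once, so their values cannot be read as one step. With no guidance, compound 4 is expected to stay close to compound 3, a step of a 1.3-fold higher number from compound 3 to compound 4 (0.12 log units; within the scatter), giving an estimated 20 nM with a range from 5 nM to 80 nM.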

Compound 4, half-maximal inhibitory concentration: 5 nM
Compound 4: middle estimate off by 4.0-fold (0.60 log units), on the high side; the range from low to high includes it.
By their numbers in this assay, from the lowest: compound 4; then compound 3; then compound 1; then compound 2.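

In this assay, the group on the aromatic ring matters as well as the chain: phenyl in place of methoxy gives a 3.0-fold lower number from compound 3 to compound 4 (0.48 log units; beyond the scatter). This position therefore takes a whole six-membered aromatic ring, and the hydrogen-bond acceptor of methoxy is not needed for a low number. No measurement shown explains this gain. Still open, on these data alone, is whether an amine or a benzyl group at this place would give a lower or a higher number. Also open, as far as these compounds go, is whether a shorter or longer chain would shift the number as strongly with phenyl present.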